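Swapping phenyl for trifluoromethyl on a sulfonyl sulfur

A few compounds are considered here, and "the series" means these few. Any claim that something is new, unique, unknown or untested is made for them only; others in the source may bear on it.

Three measured compounds share one core and differ in a single substituent. In an assay on microsomes from brain for inhibition of Fatty-acid amide hydrolase 1 (Rattus norvegicus), read by fluorescence and HPLC, with a stated time of 45 min (a lower number here means a stronger inhibitor, a higher number a weaker inhibitor), compound 1 `O=C(COc1ccc(Oc2ccccc2)cc1)Cn1ncc2cc(NC(=O)CO)ccc21` gives 5400 nM, compound 2 `O=C(COc1ccc(Oc2ccccc2)cc1)Cn1ncc2cc(NC(=O)NC3CCCCC3)ccc21` gives 840 nM, and compound 3 `O=C(COc1ccc(Oc2ccccc2)cc1)Cn1ncc2cc(C(=O)NS(=O)(=O)c3ccccc3)ccc21` gives 4700 nM. Compound 3 thus holds the second highest of the three numbers; it sits within the scatter of compound 1, while compound 2 is clearly lower, as a 5.6-fold higher number from compound 2 to compound 3 (0.75 log units; beyond the scatter) shows. Compound 4 `O=C(COc1ccc(Oc2ccccc2)cc1)Cn1ncc2cc(C(=O)NS(=O)(=O)C(F)(F)F)ccc21` differs from compound 3 by trifluoromethyl in place of phenyl on a sulfonyl sulfur. Going by the values given here, no measured step touches the sulfonyl group: a 6.4-fold lower number from compound 1 to compound 2 (0.81 log units; beyond the scatter) and a 1.1-fold lower number from compound 1 to compound 3 (0.06 log units; within the scatter) concern other parts of the molecule, so there is no direct guide. The step of no change at the digits printed from compound 3 to compound 4 (within the scatter) is expected to stay within the scatter. The estimate for compound 4 is 4700 nM, with a range from 1500 nM to 15000 nM.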

Compound 4, half-maximal inhibitory concentration: 510 nM
Beside the measured number, compound 4's estimate is 9.2-fold (0.96 log units) above it, outside the stated range (below it).
By their numbers in this assay, from the lowest: compounds 4 and 2 (each within the scatter of the next); then compounds 3 and 1 (each within the scatter of the next).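

In this assay, going by these compounds alone, trifluoromethyl in place of phenyl on the sulfonyl sulfur gives a 9.2-fold lower number from compound 3 to compound 4 (0.96 log units; beyond the scatter) and so shows that this group, untouched by the earlier steps, affects the number. Within the data shown here, the wider comparisons give an 11-fold lower number from compound 1 to compound 4 (1.02 log units; beyond the scatter) and a 1.6-fold lower number from compound 2 to compound 4 (0.22 log units; within the scatter) and so place this sulfonyl compound level with the best of the earlier compounds, not with the weaker group. Nothing given here explains the size of the change.

On these data alone, whether methyl or a longer carbon chain on the sulfonyl sulfur would give a similar number remains open. A carboxylic acid on the same aromatic carbon is also untested in the compounds shown.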